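This account rests on a few compounds, and the source may have more. Where it says the series, first, only, none or still open, it means among the compounds named here.

Compound 1 `COc1ccc2[nH]c(C(=O)N3CC(=O)N(Cc4ccccc4)[C@@H](CCc4ccccc4)C3)cc2c1` is the starting point here. Among the compounds with values here, in a physicochemical assay for solubility, read by spectrophotometry, in phosphate buffer, with a stated time of 2 h, at pH 7.4 (on this read-out higher numbers stand for higher solubility and lower numbers for lower solubility), compound 1 gives 4400 nM, one of only two numbers on hand, the other sitting within the scatter of it. That other number belongs to compound 2 `COc1cccc(CN2C(=O)CN(C(=O)c3cc4cc(OC)ccc4[nH]3)C[C@@H]2CCc2ccccc2)c1`, which gives 5100 nM in this assay; the step of a 1.2-fold higher number from compound 1 to compound 2 (0.06 log units; within the scatter), methoxy in place of hydrogen on an aromatic carbon, stays within the scatter. Compound 3 `COc1ccc2[nH]c(C(=O)N3CC(=O)N(Cc4ccccc4)[C@@H](Cc4ccccn4)C3)cc2c1` has not yet been measured. It differs from compound 1 by pyridin-2-yl in place of benzyl on a saturated chain carbon bound to a saturated ring carbon. Within the data shown here, no measured step touches a change of this kind: the single step on hand alters a different part of the core and is within the scatter, so it offers little guidance for compound 3. Compound 3 is therefore expected to give 9000 nM in this assay, with a range of 3500 nM to 25000 nM. This expectation amounts to a step of a 2.0-fold higher number from compound 1 to compound 3 (0.31 log units; beyond the scatter), held loosely for want of any comparable measured step.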

Compound 3, solubility: > 100000 nM
Compound 3 was reported as a limit (the forecaster's own chance of this, stated with the estimate: 5%); middle value at least 11-fold (1.04 log units) away from the limit.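

Benzyl to pyridin-2-yl on a saturated chain carbon bound to a saturated ring carbon gives an at least 22-fold higher number from compound 1 to compound 3 (1.35 log units; beyond the scatter) in this assay. Within the data shown here, this shows that a change at this position can move the read-out well beyond the scatter, which the only earlier step, a 1.2-fold higher number from compound 1 to compound 2 (0.06 log units; within the scatter), made elsewhere on the molecule, did not show. Compound 3 gives > 100000 nM, which is a limit and not a number, so the full size of the step cannot be read: the limit of > 100000 nM in this assay, at which 1 of the 3 values shown sits.

Read one bond further out, the change is phenethyl to (pyridin-2-yl)methyl, so the ring and the chain differ together, and the compounds shown do not separate the ring nitrogen from the chain. As far as these compounds go, a 2-(pyridin-2-yl)ethyl group at this position would keep the phenethyl chain while carrying the ring nitrogen, and how it would read remains open.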